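Taking one methoxy away from compound 2

The source may hold more compounds than are shown below. What is called first, only, known or untested is meant among the compounds shown, and "the series" means these compounds.

In a functional assay on UACC-62 cells (Homo sapiens) for inhibition, read by sulforhodamine B assay, with a stated time of 48 h (a higher number here means a weaker inhibitor of growth, a lower number a stronger inhibitor of growth), three compounds sharing one core have been measured. Compound 1 `CC1(/C=C/c2ccccc2)C=CC(=O)O1`, which carries no methoxy, gives 97200 nM. Compound 2 `COc1ccc(/C=C/C2(C)C=CC(=O)O2)c(OC)c1` gives 80100 nM, which lies within the scatter of the value for compound 1. For the measured compounds named here, compound 3 `COc1cc(OC)c(/C=C/C2(C)C=CC(=O)O2)c(OC)c1` gives 208000 nM, and only this value stands clearly apart from that of compound 2.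

The next compound to be measured is compound 4 `COc1ccccc1/C=C/C1(C)C=CC(=O)O1`. It differs from compound 2 in one place: hydrogen in place of methoxy on an aromatic carbon. In short, this is hydrogen in place of methoxy on an aromatic carbon.

Two pieces of evidence bear on this change. Going by the values given here, the one measured step adds a methoxy on another aromatic carbon: a 2.6-fold higher number from compound 2 to compound 3 (0.41 log units; beyond the scatter). This modest step concerns a different place and runs the opposite way, so it says little about this removal. Closer to the case is compound 1, which has no methoxy at all and stands at 97200 nM, within the scatter of compound 2. Compound 4 keeps a single methoxy, so no shift beyond the scatter is expected in this assay.

The estimated step is a 1.2-fold higher number from compound 2 to compound 4 (0.07 log units; within the scatter). For compound 4 the expected value is 95000 nM, with an estimated range from 50000 nM to 190000 nM.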

Compound 4, concentration for total growth inhibition: 31000 nM
Compound 4: middle estimate off by 3.1-fold (0.49 log units), on the high side; the whole stated range lies above it.
By their numbers in this assay, from the lowest: compound 4; then compounds 2 and 1 (each within the scatter of the next); then compound 3.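

In this assay, the methoxy that leaves compound 2 is not a neutral group at this place on the aromatic ring, para to the group of 9 heavy atoms: a 2.6-fold lower number from compound 2 to compound 4 (0.41 log units; beyond the scatter), so putting hydrogen there gives a stronger inhibitor of growth. Compound 4 also stands apart from the compound with no methoxy, a 3.1-fold lower number from compound 1 to compound 4 (0.50 log units; beyond the scatter), which shows that a single methoxy in the place it keeps goes with a stronger inhibitor of growth than hydrogen does, and compound 4 now has the lowest number of the four compounds. The earlier step had pointed only towards weaker inhibition when a methoxy was added, but the change of hydrogen to methoxy on an aromatic carbon has no single direction across these compounds, and its result depends on where it is made and on which core it is made: the same change on two cores in this assay, a 2.6-fold higher number (0.41 log units; beyond the scatter) from compound 2 to compound 3 and a 3.1-fold lower number (0.50 log units; beyond the scatter) from compound 1 to compound 4, 8.1-fold (0.91 log units) apart, beyond the scatter of two such steps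

The compounds shown leave open whether a hydroxy group, a fluorine atom or an amine on the aromatic carbon that lost its methoxy would keep the number as low as hydrogen does. They also leave open how a compound whose only methoxy sits on that carbon would compare with compound 1.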